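Phenyl for tert-butyl on a biaryl imidazothiazole oxime ether

This account rests on a few compounds, and the source may have more. Where it says the series, first, only, none or still open, it means among the compounds named here.

Two compounds share a core and differ only at the terminal aromatic carbon. Compound 1 `N#Cc1ccc(-c2nc3sccn3c2/C=N/OCc2ccc(Cl)c(Cl)c2)cc1` carries a cyano group and, in an assay on HepG2 cells for agonist activity at nuclear receptor subfamily 1 group I member 3 (Homo sapiens), read by a luciferase reporter, with a stated time of 23 h (on this read-out lower numbers stand for an effect already at smaller amounts and higher numbers for an effect only at larger amounts of compound), compound 1 gives 3400 nM. Compound 2 `CC(C)(C)c1ccc(-c2nc3sccn3c2/C=N/OCc2ccc(Cl)c(Cl)c2)cc1` carries a tert-butyl group, and in this assay compound 2 gives 2400 nM. The step of a 1.4-fold lower number from compound 1 to compound 2 (0.15 log units; within the scatter) is the only one at hand, and it lies within the scatter, so the two numbers cannot be told apart; compound 2 simply stands at the lower of the two printed values without that meaning anything.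

Compound 3 `Clc1ccc(CO/N=C/c2c(-c3ccc(-c4ccccc4)cc3)nc3sccn23)cc1Cl` is not yet measured. It differs from compound 2 by phenyl in place of tert-butyl on an aromatic carbon. Among the measured compounds shown here, the single measured step at this position, cyano to tert-butyl, moved nothing beyond the scatter, so no direction is indicated for a further exchange of the group at this carbon. The expectation for compound 3 in this assay is therefore no step beyond the scatter, a 1.1-fold lower number from compound 2 to compound 3 (0.04 log units; within the scatter), and compound 3 is estimated at 2200 nM, with a range from 700 nM to 7000 nM.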

Compound 3, half-maximal effective concentration: "not active" (no number reported)
Compound 3: no number reported, so the estimate cannot be set against anything.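

In this assay, among the compounds shown here, compound 3 is reported as not active, with no number, so no step from compound 2 to compound 3 can be read. Nothing at hand bears on this result. The compounds shown leave open how compound 3, with phenyl on that aromatic carbon, compares numerically with compound 1 and compound 2.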